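The source may report more compounds than this note shows. Statements on the series, on what has been measured and on what is new or still open speak of the compounds shown alone.

Measured so far in an assay on BTI cells for inhibition of Amine oxidase [flavin-containing] B (Homo sapiens), read by fluorescence, with stated times of 30 min and 1 h; on this read-out higher numbers stand for weaker inhibition and lower numbers for stronger inhibition:
Compound 1 `C[C@H](NCc1ccc(OCCCCN2CCN(c3cccc4c3ccn4Cc3cccc(Cl)c3)CC2)cc1)C(N)=O` gives > 1000 nM, which is a limit of the assay and not a number.
Compound 2 `C[C@H](NCc1ccc(OCCCCCN2CCN(c3cccc4c3ccn4Cc3cccc(Cl)c3)CC2)cc1)C(N)=O` gives > 1000 nM, likewise a limit.
Compound 3 `C#CCN(C)Cc1ccc(OCCCCN2CCN(c3cccc4c3ccn4Cc3cccc(Cl)c3)CC2)cc1` gives 323 nM.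

Compound 3 differs from compound 1 in one place: methyl(propargyl)amino in place of (1-carbamoylethyl)amino on a saturated chain carbon bound to an aromatic carbon. That change gave an at least 3.0-fold lower number from compound 1 to compound 3 (0.49 log units; beyond the scatter), a step whose size is bounded by the limit of > 1000 nM in this assay, at which 2 of the 3 values shown sit. How the core of compound 2 differs from that of compound 1 is not broken down here. Compound 4 `C#CCN(C)Cc1ccc(OCCCCCN2CCN(c3cccc4c3ccn4Cc3cccc(Cl)c3)CC2)cc1` has not yet been measured; it stands to compound 2 as compound 3 stands to compound 1, carrying the same change, (methyl(propargyl)amino in place of (1-carbamoylethyl)amino on a saturated chain carbon bound to an aromatic carbon). In this assay the step is expected to be an at least 2.8-fold lower number from compound 2 to compound 4 (0.45 log units; beyond the scatter), resting on an at least 3.0-fold lower number from compound 1 to compound 3 (0.49 log units; beyond the scatter) and on (the limit of > 1000 nM in this assay, at which 2 of the 3 values shown sit). Compound 4 is therefore estimated at 350 nM, most likely between 120 nM and 1000 nM.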

Compound 4, half-maximal inhibitory concentration: 30 nM
Compound 4: the middle estimate sits 12-fold (1.07 log units) above what was measured, and the stated range ends above it.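

In this assay, replacing (1-carbamoylethyl)amino with methyl(propargyl)amino on the core of compound 2 gives an at least 33-fold lower number from compound 2 to compound 4 (1.52 log units; beyond the scatter), so the number falls on both cores shown: the same change on two cores in this assay, an at least 3.0-fold lower number (0.49 log units; beyond the scatter) from compound 1 to compound 3 and an at least 33-fold lower number (1.52 log units; beyond the scatter) from compound 2 to compound 4; the limit leaves it open whether they differ. The direction of the change therefore carries from one core to the other, but the two sizes cannot be compared, since the steps from compound 1 and from compound 2 both start at a limit: the limit of > 1000 nM in this assay, at which 2 of the 4 values shown sit. Two cores are also too few to predict the result on a further core.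

On these data alone, it remains open whether a smaller group, such as a propargylamino or a dimethylamino group, would serve as well as methyl(propargyl)amino at this place. As far as these compounds go, the effect of a longer chain on the core also remains open.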